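Swapping 3-chlorophenyl for 2,4-difluorophenyl

The compounds below may be only part of what the source reports. "The series", "measured", "known", "first", "only" and "open" are said of these compounds alone.

- Compound 1 `CN(C)c1ccc(C=C2C(=O)N(c3ccc(Cl)cc3)N(c3ccc(Cl)cc3)C2=O)cc1` gives 80200 nM
- Compound 2 `O=C1C(=Cc2cccc(Cl)c2)C(=O)N(c2ccc(Cl)cc2)N1c1ccc(Cl)cc1` gives 14400 nM

Among the measured compounds shown here, in a functional assay on MGC-803 cells (Homo sapiens) for cytotoxicity, read by MTT assay, with a stated time of 72 h (a lower number here means a stronger inhibitor, a higher number a weaker inhibitor), compound 2 holds the lower of the two numbers measured so far (14400 nM), so it is the better of a very short series. The next analogue is compound 3 `O=C1C(=Cc2ccc(F)cc2F)C(=O)N(c2ccc(Cl)cc2)N1c1ccc(Cl)cc1`, which carries 2,4-difluorophenyl in place of 3-chlorophenyl on a double-bonded chain carbon bound to a double-bonded ring carbon and leaves the shared core untouched.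

For the measured compounds named here, only one measured step bears on this change, since it falls at the same place: a 5.6-fold lower number from compound 1 to compound 2 (0.75 log units; beyond the scatter). That step was modest, and it removed 4-(dimethylamino)phenyl, a group unlike either of the two now being exchanged. Neither measured compound carries 2,4-difluorophenyl, so the data offer no direction for this swap, and both groups are halogen-bearing phenyl rings. The step expected in this assay is therefore a 1.0-fold higher number from compound 2 to compound 3 (0.02 log units; within the scatter), which means none beyond the scatter. Compound 3 is expected at 15000 nM (from 5000 nM to 45000 nM).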

Compound 3, half-maximal inhibitory concentration: 35700 nM
For compound 3 the middle estimate is 2.4-fold (0.38 log units) below the measured one, within the range that was stated.
By their numbers in this assay, from the lowest: compound 2; then compound 3; then compound 1.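

In this assay the exchange of one halogen-bearing phenyl ring for another on a double-bonded chain carbon bound to a double-bonded ring carbon proves not to be neutral: 2,4-difluorophenyl in place of 3-chlorophenyl gives a 2.5-fold higher number from compound 2 to compound 3 (0.39 log units; beyond the scatter), so this place separates such rings from each other and not only from 4-(dimethylamino)phenyl. Measured against 4-(dimethylamino)phenyl, 2,4-difluorophenyl gives a 2.2-fold lower number from compound 1 to compound 3 (0.35 log units; beyond the scatter), which leaves both halogen-bearing rings on the lower side of compound 1, with no compound shown going against that order. No measurement is available that would account for either difference.

The change from 3-chlorophenyl to 2,4-difluorophenyl alters the kind of halogen, the number of halogen atoms and their placement on the ring all at once, so the compounds shown cannot tell which of these matters. Also open, going by these compounds, is how a phenyl ring with no substituent, a single fluorine, a methoxy group or a carboxylic acid would behave at this place.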